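Moving an Alkoxy Change from a Small Core to a Larger One

The compounds below may be only part of what the source reports. "The series", "measured", "known", "first", "only" and "open" are said of these compounds alone.

Compound 1 `CC(C)Oc1ccc(-c2cc(C(=O)O)nn2-c2ccccc2)cc1` and compound 2 `CC(C)COc1ccc(-c2cc(C(=O)O)nn2-c2ccccc2)cc1` share a small core and differ only by isobutyl in place of isopropyl on an oxygen on an aromatic ring. In an assay for displacement of a labelled ligand from E3 ubiquitin-protein ligase Mdm2 (Homo sapiens), read by fluorescence polarization, with a stated time of 30 min (a lower number here means a stronger inhibitor, a higher number a weaker inhibitor), compound 1 gives 2290 nM, while compound 2 gives 7420 nM; the step is a 3.2-fold higher number from compound 1 to compound 2 (0.51 log units; beyond the scatter), so the longer chain is the weaker of the two on this core.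

Compound 3 `CC(C)Oc1ccc(C(=O)Nc2c(C(=O)O)nn(-c3ccc(Oc4ccccc4)cc3)c2-c2ccc(OC(C)C)cc2)cc1` is built on a much larger core. The difference between the core of compound 3 and the core of compound 1 is not broken down here. In this assay compound 3 gives 107 nM, the lowest number of the three measured compounds and well below both compound 1 and compound 2.

Compound 4 `CC(C)COc1ccc(C(=O)Nc2c(C(=O)O)nn(-c3ccc(Oc4ccccc4)cc3)c2-c2ccc(OC(C)C)cc2)cc1` is what compound 3 becomes after (isobutyl in place of isopropyl on an oxygen on an aromatic ring). The place of the change is worded the same as for the pair of compound 1 and compound 2, so this is the same change, now carried out on the larger core. Within the data shown here, whether a change transfers from a small core to a larger one is not guaranteed, and only one earlier example of it is available here.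

Among the measured compounds shown here, compound 4 is expected to show a step of a 2.6-fold higher number from compound 3 to compound 4 (0.42 log units; beyond the scatter) in this assay, because the same change gave a 3.2-fold higher number from compound 1 to compound 2 (0.51 log units; beyond the scatter) and nothing among the measured compounds argues against a loss of similar size. On that basis compound 4 is estimated at 280 nM, with a likely range from 120 nM to 700 nM.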

Compound 4, inhibition constant: 422 nM
Estimate against measurement, compound 4: 1.5-fold (0.18 log units) below, and the stated range covers the measured number.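

On the larger core, isobutyl in place of isopropyl on an oxygen on an aromatic ring gives a 3.9-fold higher number from compound 3 to compound 4 (0.60 log units; beyond the scatter) in this assay, so the longer chain is again the weaker member of the pair. Set beside the result on the small core, the change carries over in both direction and size: the same change on two cores in this assay, a 3.2-fold higher number (0.51 log units; beyond the scatter) from compound 1 to compound 2 and a 3.9-fold higher number (0.60 log units; beyond the scatter) from compound 3 to compound 4, 1.2-fold (0.09 log units) apart, within the scatter of two such steps

This shows that, for these two pairs, the large difference between the cores did not alter what this one change does to the measured number, but it does not show that the same would hold on a third core or for any other change, and it gives no reason for the loss.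

As far as these compounds go, it remains open whether a shorter group on the same oxygen, such as methyl or ethyl, or a longer chain, such as n-pentyl, would fit the same picture on both cores. Also open, from the compounds shown here alone, is whether the same swap would behave alike at the other isopropoxy group of compound 3, and whether the carboxylic acid shared by all four compounds could be replaced by an amide or a tetrazole.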